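Working notes: carbonyl substituent change, compound 2 to compound 3

A few compounds are considered here, and "the series" means these few. Any claim that something is new, unique, unknown or untested is made for them only; others in the source may bear on it.

Compound 1 `O=C(Nc1ccc(Cl)c(Cl)c1)N[C@@H]1C2CCN(CC2)[C@@H]1Cc1cccnc1` and compound 2 `O=C(NCc1ccc(Br)cc1)N[C@@H]1C2CCN(CC2)[C@@H]1Cc1cccnc1` share one core and differ only in the group on the amide-type nitrogen. In an assay on a protein complex for binding affinity to Neuronal acetylcholine receptor; alpha4/beta2 (Homo sapiens) (on this read-out lower numbers stand for stronger inhibition and higher numbers for weaker inhibition), compound 1 gives > 10000 nM, which is a limit of the assay and not a number. In this assay compound 2 likewise gives > 10000 nM, again a limit. The step that the two limits leave unreadable from compound 1 to compound 2 is therefore unreadable, and compound 2 stands only at a limit, with no number to place it. Both values sit at the same limit, as the limit of > 10000 nM in this assay, at which 2 of the 2 values shown sit, records.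

Compound 3 `Cn1cccc1C(=O)N[C@@H]1C2CCN(CC2)[C@@H]1Cc1cccnc1` differs from compound 2 by 1-methyl-1H-pyrrol-2-yl in place of (4-bromobenzyl)amino on a carbonyl carbon. For the measured compounds named here, no measured step bears on this change: the single step recorded, from compound 1 to compound 2, is unreadable and concerns the amide-type nitrogen, not the carbonyl carbon. With both measured values at the limit, neither direction nor size can be read for this assay, and the expectation is that compound 3 stays near the limit. Compound 3 is estimated at 10000 nM, in the range 2000 nM to 50000 nM, an expected step of a number no higher from compound 2 to compound 3 (the limit leaves the size open).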

Compound 3, inhibition constant: > 10000 nM
Compound 3 gave a limit, no number; the forecaster's own chance of this, stated with the estimate: 60%; the middle value sits exactly at the limit.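

In this assay compound 3 gives > 10000 nM, a limit of the assay and not a number. No new step can be read, neither to compound 3 from compound 2 nor to compound 3 from compound 1; all three compounds share one limit: the limit of > 10000 nM in this assay, at which 3 of the 3 values shown sit.

The compounds shown leave open which group on the carbonyl carbon of the shared core, if any, would give a number in this assay.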